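The source may report more compounds than this note shows. Statements on the series, on what has been measured and on what is new or still open speak of the compounds shown alone.

Values in a functional assay on U-87MG ATCC cells (Homo sapiens) for antiproliferative activity (a higher number here means a weaker inhibitor, a lower number a stronger inhibitor), follow.

- compound 1 `Cc1c2c(n3c1CCNC[C@@H](C)[C@H](C)Nc1cc-3ccc1C(N)=O)CC(C)(C)CC2=O` gives 40 nM
- compound 2 `Cc1c2c(n3c1CCN(C)C[C@@H](C)[C@H](C)Nc1cc-3ccc1C(N)=O)CC(C)(C)CC2=O` gives 49 nM
- compound 3 `Cc1c2c(n3c1CCN(C(=O)[C@@H](N)C(C)C)C[C@@H](C)[C@H](C)Nc1cc-3ccc1C(N)=O)CC(C)(C)CC2=O` gives 48 nM

Compound 3 at 48 nM stands level with compound 1 and compound 2, all three values lying within the scatter of one another.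

Compound 4 `Cc1c2c(n3c1CCN(C(=O)C1(N)CC1)C[C@@H](C)[C@H](C)Nc1cc-3ccc1C(N)=O)CC(C)(C)CC2=O` differs from compound 3 in one group 1-aminocyclopropyl in place of 1-amino-2-methylpropyl on a carbonyl carbon with 1-aminocyclopropyl in place of 1-amino-2-methylpropyl on a carbonyl carbon.

Within the data shown here, no measured pair tests this exchange directly. The closest evidence comes from changes on the same amine nitrogen in a ring. The step of a 1.2-fold higher number from compound 1 to compound 2 (0.09 log units; within the scatter) for methyl in place of hydrogen, the step of a 1.2-fold higher number from compound 1 to compound 3 (0.08 log units; within the scatter) for (1-amino-2-methylpropyl)carbonyl in place of hydrogen and the step of a 1.0-fold lower number from compound 2 to compound 3 (0.01 log units; within the scatter) for that group in place of methyl all lie within the scatter. This flat picture holds for these three compounds only, and none of them carries the three-membered ring, so the range is kept wide.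

No step beyond the scatter is expected in this assay for this exchange. The estimated step is a 1.0-fold higher number from compound 3 to compound 4 (0.02 log units; within the scatter) and would lie within the scatter. For compound 4 the expected value is 50 nM with an estimated range of 25 nM to 110 nM in this read-out.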

Compound 4, half-maximal inhibitory concentration: 85 nM
Estimate against measurement, compound 4: 1.7-fold (0.23 log units) below; low and high end bracket the measured number.
By their numbers in this assay, from the lowest: compounds 1, 3, 2 and 4 (each within the scatter of the next, the first and the last beyond it).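

In this assay the exchange on a carbonyl carbon, 1-aminocyclopropyl in place of 1-amino-2-methylpropyl, reads as a 1.8-fold higher number from compound 3 to compound 4 (0.25 log units; within the scatter), and the comparison with the methyl compound reads as a 1.7-fold higher number from compound 2 to compound 4 (0.24 log units; within the scatter), so neither step separates compound 4 from its neighbours. The one separation in the set appears against the unsubstituted amine nitrogen in a ring, as a 2.1-fold higher number from compound 1 to compound 4 (0.33 log units; beyond the scatter), so this position, flat across the first three compounds, is not wholly indifferent to what it carries: (1-aminocyclopropyl)carbonyl moves modestly away from compound 1, whereas (1-amino-2-methylpropyl)carbonyl stays within the scatter of it. Nothing available here speaks to the origin of this modest step.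

From the compounds shown here alone, whether 1-aminocyclobutyl or a plain aminomethyl on the same carbonyl carbon would read with compound 3, with compound 4 or elsewhere remains open. Also open, going by these compounds, is the part played by the amine in these acyl groups, which a simple isobutyl or cyclopropyl on that carbonyl carbon would test against compound 3 and compound 4.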